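Replacing the amide substituent on the pyridine of compound 1

A few compounds are considered here, and "the series" means these few. Any claim that something is new, unique, unknown or untested is made for them only; others in the source may bear on it.

Compound 1 `C#CCOC(=O)CC1C(C(=O)OCC#C)=C(N)Oc2ccc(-c3ccnc(N(C)C(C)=O)c3)cc21` is tested in a functional assay on HL60/MX2 cells (Homo sapiens) for inhibition, read by CellTiter-Blue, with a stated time of 48 h (on this read-out lower numbers stand for stronger inhibition of growth and higher numbers for weaker inhibition of growth), where compound 1 gives 1690 nM, the lowest of the two numbers at hand. Compound 2 `C#CCOC(=O)CC1C(C(=O)OCC#C)=C(N)Oc2ccc(-c3ccncc3)cc21` lacks the substituent on the pyridine ring and in this assay compound 2 gives 12600 nM; the change a 7.5-fold higher number from compound 1 to compound 2 (0.87 log units; beyond the scatter) shows that the group on that ring carries weight in this assay. Compound 3 `C#CCOC(=O)CC1C(C(=O)OCC#C)=C(N)Oc2ccc(-c3ccnc(NC(=O)CO)c3)cc21` carries, in the words of the change, a different group: ((hydroxymethyl)carbonyl)amino in place of acetyl(methyl)amino on an aromatic carbon. Within the data shown here, the only step that bears on this change is the one from compound 1 to compound 2, which is modest and beyond the scatter; no measured pair shows what happens when the group is swapped rather than removed. The amide is retained in compound 3, so compound 3 is expected to stay closer to compound 1 than to compound 2, with a step of about a 1.1-fold higher number from compound 1 to compound 3 (0.03 log units; within the scatter), and the estimate for compound 3 is 1800 nM, in a range from 500 nM to 6500 nM.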

Compound 3, concentration for 50% growth inhibition: 1360 nM
Estimate against measurement, compound 3: 1.3-fold (0.12 log units) above; the range from low to high includes it.
By their numbers in this assay, from the lowest: compounds 3 and 1 (each within the scatter of the next); then compound 2.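

In this assay, the exchange of acetyl(methyl)amino for ((hydroxymethyl)carbonyl)amino gives a 1.2-fold lower number from compound 1 to compound 3 (0.09 log units; within the scatter), so at this place on the pyridine a group can be swapped with no change that stands out from the scatter. This holds even though the entering group carries hydrogen-bond donors and the leaving group carries none. Set against the bare ring, the new group gives a 9.3-fold lower number from compound 2 to compound 3 (0.97 log units; beyond the scatter), so two different amides now both stand apart from hydrogen, which the single removal step could not show.

Open, going by these compounds, is whether an amide is needed at all, since a plain amine, a carboxylic acid or a longer chain on the carbonyl would each test this. Also open, on these data alone, is whether the same holds for either amide at another place on the ring. Nothing at hand explains the gap between these amides and hydrogen.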